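Benzofuran amidoximes against indoleamine 2,3-dioxygenase 1

A few compounds are considered here, and "the series" means these few. Any claim that something is new, unique, unknown or untested is made for them only; others in the source may bear on it.

Compound 1 `O/N=C(/Nc1ccccc1)c1ccc2occc2c1` and compound 2 `O/N=C(/Nc1ccc(Cl)cc1)c1ccc2occc2c1` share one core. In an assay on isolated protein for inhibition of Indoleamine 2,3-dioxygenase 1 (Homo sapiens), read by spectrophotometry (a higher number here means a weaker inhibitor, a lower number a stronger inhibitor), compound 1 reports only a limit, > 30000 nM. Compound 2 likewise gives only a limit, > 30000 nM. The change between them, (chloro in place of hydrogen on an aromatic carbon), makes a step that the two limits leave unreadable from compound 1 to compound 2. Compound 3 `O/N=C(/NCc1ccccc1)c1ccc2occc2c1` differs from compound 1 in more than one place; the difference between the two cores is not broken down here. In this assay compound 3 also shows only a limit, > 30000 nM. Compound 4 `O/N=C(/NCc1cccc(Cl)c1)c1ccc2occc2c1` is not yet measured; it differs from compound 3 by chloro in place of hydrogen on an aromatic carbon, the same kind of change as from compound 1 to compound 2, here placed meta to a large group rather than para to a large group. For the measured compounds named here, since every value so far sits at the limit of > 30000 nM in this assay, at which 3 of the 3 values shown sit, the step from compound 3 to compound 4 is expected to be a step that the limit leaves unreadable from compound 3 to compound 4. Compound 4 is therefore estimated at 40000 nM, most likely again reported only as a limit.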

Compound 4, half-maximal inhibitory concentration: > 30000 nM
Compound 4: no number, only a limit (the forecaster's own chance of this, stated with the estimate: 85%); the middle value lies beyond the limit too.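

In this assay compound 4 gives > 30000 nM, a limit and not a number. For the compounds shown here, no step between compound 3 and compound 4 can be read. The compounds shown leave open how strongly any of them inhibits, and whether chloro in place of hydrogen changes that.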